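Amino-to-nitro swap on the aryl ketone of a chalcone series

The source may hold more compounds than are shown below. What is called first, only, known or untested is meant among the compounds shown, and "the series" means these compounds.

Measured so far:
compound 1 `COc1ccc(-c2cc3ccccc3nc2/C=C/C(=O)c2ccc(OC)cc2OC)cc1` 6110 nM
compound 2 `COc1ccc(-c2cc3ccccc3nc2/C=C/C(=O)c2ccc(N)cc2)cc1` 9290 nM

Among the measured compounds shown here, compound 2 gives the highest of the two numbers in a functional assay on H184B5F5/M10 cells (Homo sapiens) for antiproliferative activity, read by XTT assay, with a stated time of 72 h (on this read-out lower numbers stand for stronger inhibition and higher numbers for weaker inhibition), and its only neighbour is compound 1, separated by a 1.5-fold higher number from compound 1 to compound 2 (0.18 log units; within the scatter). Compound 3 `COc1ccc(-c2cc3ccccc3nc2/C=C/C(=O)c2ccc([N+](=O)[O-])cc2)cc1` differs from compound 2 by nitro in place of amino on an aromatic carbon. For the measured compounds named here, no measured step exchanges amino for nitro; the only step available, on the other aryl group, stays within the scatter. The expected step in a 1.2-fold lower number from compound 2 to compound 3 (0.06 log units; within the scatter) is therefore small, with no direction claimed beyond the scatter. Compound 3 is estimated at 8000 nM in this assay, with a range from 3000 nM to 25000 nM.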

Compound 3, half-maximal inhibitory concentration: 6100 nM
The estimate for compound 3 lay 1.3-fold (0.12 log units) above the measured number; the range from low to high includes it.
By their numbers in this assay, from the lowest: compounds 3, 1 and 2 (each within the scatter of the next).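

In this assay the swap on this aromatic carbon gives a 1.5-fold lower number from compound 2 to compound 3 (0.18 log units; within the scatter) and so does not separate amino from nitro. The 4-nitrophenyl ketone likewise shows a 1.0-fold lower number from compound 1 to compound 3 (0.00 log units; within the scatter) against the 2,4-dimethoxyphenyl ketone of the shared core, which puts all three aryl ketones within the scatter of one another. Nothing available explains this flat result.

Going by these compounds, whether a carboxylic acid or a nitrile on this carbon would move the number beyond the scatter remains open. So does the reading of an unsubstituted phenyl ketone.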